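Working notes on compound 4 from compound 1

This account rests on a few compounds, and the source may have more. Where it says the series, first, only, none or still open, it means among the compounds named here.

Measured so far in a functional assay on HL-60 cells (Homo sapiens) for inhibition, read by MTT assay, with a stated time of 72 h; on this read-out lower numbers stand for stronger inhibition and higher numbers for weaker inhibition:
compound 1 `Cc1nc(-c2ccccc2)c(C(=O)N2CCN(c3cccc(Cl)c3Cl)CC2)o1`: 133 nM
compound 2 `CCc1nc(-c2ccc(OC)c(OC)c2)c(C(=O)N2CCN(c3cccc(Cl)c3)CC2)o1`: "not active" (no number reported)
compound 3 `Cc1nc(-c2ccccc2Cl)c(C(=O)N2CCN(c3cccc(Cl)c3)CC2)o1`: 132 nM

Compound 1 holds the higher of the two reported numbers, but compound 3 sits within the scatter of it, so the two are not distinguishable. Compound 2 gave no number in this assay. Compound 4 `Cc1nc(-c2ccccc2)c(C(=O)N2CCN(c3ccccc3C(F)(F)F)CC2)o1` is not yet measured; it differs from compound 1 by 2-(trifluoromethyl)phenyl in place of 2,3-dichlorophenyl on an amine nitrogen in a ring. Going by the values given here, no step between measured compounds informs this change, and nothing shows that a group of this kind on the ring nitrogen shifts the number. A step of no more than the usual scatter is therefore expected, with no clear direction. Compound 4 is estimated at 150 nM, range 50 nM to 450 nM, an expected step of a 1.1-fold higher number from compound 1 to compound 4 (0.05 log units; within the scatter).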

Compound 4, half-maximal inhibitory concentration: 120 nM
Compound 4: middle estimate off by 1.3-fold (0.10 log units), on the high side; the range from low to high includes it.
By their numbers in this assay, from the lowest: compounds 4, 3 and 1 (each within the scatter of the next).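

In this assay, exchanging 2,3-dichlorophenyl for 2-(trifluoromethyl)phenyl on the ring nitrogen gives a 1.1-fold lower number from compound 1 to compound 4 (0.04 log units; within the scatter), so this position now has a step that can be read. This exchange, with its two extra heavy atoms, leaves the number within the scatter. No measurement here bears on why the two groups read alike.

Going by these compounds, whether the number at this position can move beyond the scatter remains open. So does the outcome with an amine or a carboxylic acid on the phenyl ring in place of trifluoromethyl.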